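This account rests on a few compounds, and the source may have more. Where it says the series, first, only, none or still open, it means among the compounds named here.

Compound 2 `O=C(Nc1ccccc1F)c1cccc(N2C(=O)c3ccccc3C2=O)c1` carries a 2-fluorophenyl group on an amide-type nitrogen attached to the shared core. In an in vitro functional assay on HEK293-A cells for antagonist activity at metabotropic glutamate receptor 5 (Rattus norvegicus), read by calcium flux (on this read-out higher numbers stand for weaker inhibition and lower numbers for stronger inhibition), compound 2 gives 1050 nM. Among the measured compounds shown here, of the two numbers measured so far this is the lower one; its only neighbour is compound 1 `COc1cc(NC(=O)c2cccc(N3C(=O)c4ccccc4C3=O)c2)cc(OC)c1`, which in this assay gives 3580 nM, and the step of a 3.4-fold lower number from compound 1 to compound 2 (0.53 log units; beyond the scatter) shows what exchanging one substituted phenyl for another at that nitrogen did. Compound 3 `O=C(NC1CC1)c1cccc(N2C(=O)c3ccccc3C2=O)c1` has not yet been measured. It differs from compound 2 in one place: cyclopropyl in place of 2-fluorophenyl on an amide-type nitrogen. For the measured compounds named here, the single measured step bears on this change only loosely. It shows that the group on the amide-type nitrogen shifts the number beyond the scatter, but it compares two six-membered aromatic rings, whereas here an aromatic ring gives way to a three-membered non-aromatic ring. The direction is uncertain, and the number for compound 3 is expected to rise rather than fall. For compound 3 the expected step is a 2.9-fold higher number from compound 2 to compound 3 (0.46 log units; beyond the scatter). Compound 3 is estimated at 3000 nM in this assay, with a range from 800 nM to 12000 nM.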

Compound 3, half-maximal inhibitory concentration: > 30000 nM
Compound 3 was reported as a limit (the forecaster's own chance of this, stated with the estimate: 15%); middle value at least 10-fold (1.00 log units) away from the limit.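

The earlier step exchanged one substituted phenyl for another at the amide-type nitrogen and moved the number only modestly, whereas giving up the aromatic ring for cyclopropyl in this assay has a far larger effect, with an at least 28-fold higher number from compound 2 to compound 3 (1.45 log units; beyond the scatter) and an at least 8.3-fold higher number from compound 1 to compound 3 (0.92 log units; beyond the scatter). Among the three compounds, the two that carry a substituted phenyl on this nitrogen both give measured numbers, and only the cyclopropyl compound reaches the end of the range, so this position tolerates a change of substituents on the phenyl ring far better than the loss of that ring. Compound 3 is reported only as a limit and not as a number, which leaves the true size of both steps unknown: the limit of > 30000 nM in this assay, at which 1 of the 3 values shown sits.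

The compounds shown do not tell whether the aromatic ring itself matters or whether any group with as many atoms would serve, and a cyclohexyl ring or a benzyl group on the same nitrogen would separate the two. They also leave open what an unsubstituted phenyl or a pyridine ring would give at this nitrogen, and so how much of the number of compound 2 depends on its fluorine.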